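Trimethylammonium for amine in a sulfonamide piperazine series

A few compounds are considered here, and "the series" means these few. Any claim that something is new, unique, unknown or untested is made for them only; others in the source may bear on it.

Measured compounds in an assay on isolated protein for binding affinity to B1 bradykinin receptor (Homo sapiens); a higher number here means a weaker inhibitor, a lower number a stronger inhibitor:
Compound 1 `Cc1cc(C)c2cccc(OCc3c(Cl)ccc(S(=O)(=O)NC4(C(=O)N5CCN(C(=O)C[C@@H](N)CCCN)CC5)CCCC4)c3Cl)c2n1` gives < 10000 nM, a limit.
Compound 2 `Cc1cc(C)c2cccc(OCc3c(Cl)ccc(S(=O)(=O)NC4(C(=O)N5CCN(C(=O)C[C@@H](N)CCC[N+](C)(C)C)CC5)CCCC4)c3Cl)c2n1` gives < 10000 nM, a limit.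
Compound 3 `Cc1cc(C)c2cccc(OCc3c(Cl)ccc(S(=O)(=O)NC4(C(=O)N5CCN(C(=O)[C@@H](N)CCC[N+](C)(C)C)CC5)CCCC4)c3Cl)c2n1` gives < 10000 nM, a limit.

Among the measured compounds shown here, all three measured values are limits of this assay and not numbers, so the limit of < 10000 nM in this assay, at which 3 of the 3 values shown sit, is the only evidence on the measured steps. The change a group of 4 heavy atoms (3 carbon, 1 nitrogen; no ring) in place of one nitrogen atom, on a saturated chain carbon, four bonds along the chain from an amine nitrogen made a step that the two limits leave unreadable from compound 1 to compound 2. The core of compound 3 differs from that of compound 1 by a group of 9 heavy atoms (7 carbon, 2 nitrogen; no ring) in place of a group of 7 heavy atoms (5 carbon, 2 nitrogen; no ring), on a carbonyl carbon, and a step that the two limits leave unreadable from compound 1 to compound 3 and a step that the two limits leave unreadable from compound 2 to compound 3 are likewise unreadable.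

Compound 4 `Cc1cc(C)c2cccc(OCc3c(Cl)ccc(S(=O)(=O)NC4(C(=O)N5CCN(C(=O)[C@H](CCC[N+](C)(C)C)[N+](C)(C)C)CC5)CCCC4)c3Cl)c2n1` is not yet measured. It carries the same kind of change as compound 2, namely (a group of 4 heavy atoms (3 carbon, 1 nitrogen; no ring) in place of one nitrogen atom, on a saturated chain carbon bound to a carbonyl carbon and a saturated chain carbon), but the place differs: in compound 2 it sits on a saturated chain carbon, four bonds along the chain from an amine nitrogen, whereas in compound 4 it sits on a saturated chain carbon bound to a carbonyl carbon and a saturated chain carbon. In this assay the step from compound 3 to compound 4 is expected to be a step that the limit leaves unreadable from compound 3 to compound 4, resting on the unreadable a step that the two limits leave unreadable from compound 1 to compound 2 and on (the limit of < 10000 nM in this assay, at which 3 of the 3 values shown sit). For compound 4 the estimate is 3000 nM, within 200 nM to 10000 nM.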

Compound 4, inhibition constant: < 10000 nM
Compound 4: no number, only a limit; the forecaster's own chance of this, stated with the estimate: 70%; the middle value does not contradict the limit.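

In this assay compound 4 gives < 10000 nM, a limit and not a number. No step from compound 1, compound 2 or compound 3 to compound 4 can be read, and the evidence stays as it was: the limit of < 10000 nM in this assay, at which 4 of the 4 values shown sit.

The compounds shown leave open whether any of these changes shifts the inhibition constant, and by how much.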